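This account rests on a few compounds, and the source may have more. Where it says the series, first, only, none or still open, it means among the compounds named here.

Notes on the series. Compound 1 `CCC1(Cc2ccccc2)OS(=O)(=O)C=C1OC` in an ADME assay on HEL cells (Homo sapiens) for cytotoxicity, with a stated time of 3 days (a lower number here means that less compound is tolerated, a higher number that more compound is tolerated), gives > 400000 nM; this is a limit of the assay and not a number, so compound 1 stands at the upper edge of what can be reported here. Compound 2 `CCCC1(Cc2ccccc2)OS(=O)(=O)C=C1OCc1ccccc1` likewise returns only a limit in this assay, namely >= 400000 nM. Nothing more can be drawn from the pair than that both recorded values rest at the limit, as the limit of > 400000 nM in this assay, at which 1 of the 2 values shown sits, and the limit of >= 400000 nM in this assay, at which 1 of the 2 values shown sits, show.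

Compound 3 `C=CCOC1=CS(=O)(=O)OC1(CC)Cc1ccccc1` is not yet measured. It differs from compound 1 in a single place: vinyl in place of hydrogen on a saturated chain carbon bound to an oxygen on an unsaturated carbon. Within the data shown here, no measured step in this assay covers a change of this kind, so the size of the step cannot be read from the data. With compound 1 resting at the limit, the expected step is none beyond the scatter, a number no higher from compound 1 to compound 3 (the limit leaves the size open), and the most likely outcome is that compound 3 again returns only a limit. The estimate for compound 3 in this assay is 400000 nM, within a range from 150000 nM to 400000 nM.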

Compound 3, minimum cytotoxic concentration: 80000 nM
Compound 3: middle estimate off by 5.0-fold (0.70 log units), on the high side, and the stated range ends above it.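

At the place printed for this change, a saturated chain carbon bound to an oxygen on an unsaturated carbon, going from methoxy to allyloxy gives an at least 5.0-fold lower number from compound 1 to compound 3 (0.69 log units; beyond the scatter) in this assay, so this position can move the read-out, which the two limits alone could not show. The change is small, vinyl in place of hydrogen with 2 heavy atoms and 1 double bond outside aromatic rings, yet in this series compound 3 gives a measured number rather than a limit, 80000 nM. The full size of the step stays open because compound 1 rests at a limit and not at a number: the limit of > 400000 nM in this assay, at which 1 of the 3 values shown sits.

Among these compounds, compound 2 differs from both compound 1 and compound 3 in more than one place, so no step involving it can be read. On these data alone, whether the lower number follows the double bond or the longer chain stays open, and a saturated propyl chain on the same oxygen would separate the two.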